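The compounds below may be only part of what the source reports. "The series", "measured", "known", "first", "only" and "open" are said of these compounds alone.

Compound 1 `CNC(=O)[C@@H](c1ccccc1)N1CCn2c(C3CC3)nc(Cl)c2[C@@H]1CCc1cccc(C(F)(F)F)c1`: 91 nM in a functional assay on CHO cells for antagonist activity at Orexin/Hypocretin receptor type 1 (Homo sapiens), read by FLIPR and calcium flux; on this read-out higher numbers stand for weaker inhibition and lower numbers for stronger inhibition
Compound 2 `CNC(=O)[C@@H](c1ccccc1)N1CCn2c(C3CC3)nc(Cl)c2[C@@H]1CCc1ccc(C(F)(F)F)cc1F`: 94 nM

Compound 2 and compound 1 lie within the scatter of each other in this assay, as the step of a 1.0-fold higher number from compound 1 to compound 2 (0.01 log units; within the scatter) shows. Compound 3 `CNC(=O)[C@@H](c1ccccc1)N1CCn2c(C3CC3)nc(Cl)c2[C@@H]1CCc1ccc(OC(F)F)c(F)c1` is not yet measured. It differs from compound 2 by 4-(difluoromethoxy)-3-fluorophenyl in place of 2-fluoro-4-(trifluoromethyl)phenyl on a saturated chain carbon, two bonds along the chain from a saturated ring carbon. For the measured compounds named here, the only measured step, a 1.0-fold higher number from compound 1 to compound 2 (0.01 log units; within the scatter), also exchanged the aryl group on this chain carbon and stayed within the scatter, so a change of at most modest size is expected here, in no firm direction; the expected step is a 1.3-fold higher number from compound 2 to compound 3 (0.11 log units; within the scatter). Compound 3 is therefore estimated at 120 nM, with a range from 45 nM to 350 nM.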

Compound 3, half-maximal inhibitory concentration: 170 nM
The estimate for compound 3 lay 1.4-fold (0.15 log units) below the measured number; measured number inside the range.
By their numbers in this assay, from the lowest: compounds 1, 2 and 3 (each within the scatter of the next).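

In this assay the exchange on this chain carbon gives a 1.8-fold higher number from compound 2 to compound 3 (0.26 log units; within the scatter) and, measured against the other aryl group, a 1.9-fold higher number from compound 1 to compound 3 (0.27 log units; within the scatter) as well. A 4-(difluoromethoxy)-3-fluorophenyl group, which brings an oxygen and a hydrogen-bond acceptor to this place, therefore reads within the scatter of both aryl groups that carry no oxygen. Nothing available offers an explanation for this result. The compounds shown leave open how an aryl group carrying an amine or a carboxylic acid would read here. They also leave open whether a longer chain to the aryl ring would hold this level.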